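Replacing the Ring Carboxylic Acid with Isopropyl

The source may hold more compounds than are shown below. What is called first, only, known or untested is meant among the compounds shown, and "the series" means these compounds.

Compound 1 `CC(C)(C)[C@H]1CC[C@H](N(Cc2ccc(C(=O)NCCC(=O)O)cc2)C(=O)Nc2ccc(C#N)cc2OC(F)(F)F)CC1`: in an in vitro assay on BHK cells for inhibition of Glucagon receptor (Homo sapiens) (a higher number here means a weaker inhibitor, a lower number a stronger inhibitor), compound 1 gives 215 nM.
Compound 2 `CC(C)(C)[C@H]1CC[C@H](N(Cc2ccc(C(=O)NCCC(=O)O)cc2)C(=O)Nc2ccc(OCC3CC3)cc2C(F)(F)F)CC1`: in this assay compound 2 gives 182 nM.
Compound 3 `O=C(O)CCNC(=O)c1ccc(CN(C(=O)Nc2ccc(OC(F)(F)F)cc2)C2CCC(C(=O)O)CC2)cc1`: in this assay compound 3 reaches only a limit, > 10000 nM.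

Compound 3 thus stands apart from the other two: it sits at the limit of > 10000 nM in this assay, at which 1 of the 3 values shown sits, where no number is reported. Compound 4 `CC(C)C1CCC(N(Cc2ccc(C(=O)NCCC(=O)O)cc2)C(=O)Nc2ccc(OC(F)(F)F)cc2)CC1` differs from compound 3 by isopropyl in place of carboxy on a saturated ring carbon. Among the compounds with values here, no measured pair differs in that one place, so the step cannot be read off directly. Compound 1 with 215 nM and compound 2 with 182 nM carry no carboxy on that ring and both give a measured number. The expected step is therefore a large gain: an at least 20-fold lower number from compound 3 to compound 4 (1.30 log units; beyond the scatter). Compound 4 is estimated at 500 nM, within 100 nM to 5000 nM.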

Compound 4, half-maximal inhibitory concentration: 59 nM
Estimate against measurement, compound 4: 8.5-fold (0.93 log units) above; measured number below the stated range.
By their numbers in this assay, from the lowest: compound 4; then compounds 2 and 1 (each within the scatter of the next). At a limit, above all of these: compound 3.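

Within the data shown here, compounds 3 and 4 form the first pair that differs only at this ring position, and the change from 4-carboxycyclohexyl to 4-isopropylcyclohexyl gives an at least 160-fold lower number from compound 3 to compound 4 (2.22 log units; beyond the scatter) in this assay. With all else held constant, this one ring substituent decides whether a number can be measured at all. The step is only a lower bound because compound 3 stands at a limit and not at a number: the limit of > 10000 nM in this assay, at which 1 of the 4 values shown sits.

The compounds shown leave open how an amine, a hydroxyl group or a longer alkyl chain would fare on this ring carbon. They also do not separate the loss of carboxy from the gain of isopropyl.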